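Ureidopyrimidine anilines: a methoxy-for-trifluoromethyl swap, twice

A few compounds are considered here, and "the series" means these few. Any claim that something is new, unique, unknown or untested is made for them only; others in the source may bear on it.

Three ureidopyrimidines carrying a substituted aniline have been measured in a functional assay on NCI-H226 cells (Homo sapiens) for inhibition, read by MTT assay, with a stated time of 48 h, tested at 10 uM; on this read-out higher numbers stand for more inhibition at the one concentration tested (going by the name of the read-out) and lower numbers for less inhibition. Compound 1 `COc1ccc(C(F)(F)F)cc1Nc1cc(NC(=O)Nc2c(Cl)cccc2Cl)ncn1` gives 60.1% in this assay, compound 2 `COc1cc(Nc2cc(NC(=O)Nc3c(Cl)cccc3Cl)ncn2)cc(OC)c1` gives 60%, and compound 3 `COc1cc(Nc2cc(NC(=O)Nc3c(Cl)cccc3Cl)ncn2)cc(C(F)(F)F)c1` gives 33.1%. The numbers for compound 1 and compound 2 lie within the usual scatter of each other, so no order can be read between them; compound 3 sits well apart from both. Compound 1 and compound 3 contain the same atoms joined differently, and how their cores differ is not broken down here.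

Between compound 3 and compound 2 one change is made, (methoxy in place of trifluoromethyl on an aromatic carbon), and it gave a number 26.9 percentage points higher from compound 3 to compound 2 (beyond the scatter).

Compound 4 `COc1ccc(OC)c(Nc2cc(NC(=O)Nc3c(Cl)cccc3Cl)ncn2)c1` has not yet been measured. It arises from compound 1 by methoxy in place of trifluoromethyl on an aromatic carbon. Within the data shown here, this is the same kind of change as the one from compound 3 to compound 2, but not the same: in compound 4 the new methoxy sits para to a methoxy group, whereas in compound 2 it sits meta to a methoxy group.

Because compound 1 already reaches 60.1%, the room for a further rise is smaller than the step seen from compound 3 to compound 2, and compound 4 is expected to move by a number 7.9 percentage points higher from compound 1 to compound 4 (within the scatter). Compound 4 is therefore estimated at 68% in this assay, with an expected range from 50% to 85%.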

Compound 4, a percentage reported as inhibition, at one concentration (the size of the read-out at that concentration, not a potency): 81.7%
Beside the measured number, compound 4's estimate is 13.7 percentage points below it; low and high end bracket the measured number.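

Swapping trifluoromethyl for methoxy on the core of compound 1 gave a number 21.6 percentage points higher from compound 1 to compound 4 (beyond the scatter) in this assay, so the change raised the read-out on this core as well. This shows only that, across the two pairs available, the change moved the number in the same direction, and it does not show that the same would hold on any further core. A reading at one concentration does not give a potency. What lies behind the rise is not shown by these data. On these two cores, the step carried over with no difference in size that can be told apart: the same change on two cores in this assay, a number 26.9 percentage points higher (beyond the scatter) from compound 3 to compound 2 and a number 21.6 percentage points higher (beyond the scatter) from compound 1 to compound 4, 5.3 percentage points apart, within the scatter of two such steps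

The compounds shown leave open whether another group in the same place, such as a nitrile, an amine, a carboxylic acid or a longer alkoxy chain like ethoxy, would give a similar number to methoxy. They also leave open whether the step would survive a change elsewhere in the molecule, for instance if the two chlorines on the urea side were replaced by fluorine or by methyl groups.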